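A few compounds are considered here, and "the series" means these few. Any claim that something is new, unique, unknown or untested is made for them only; others in the source may bear on it.

Measured in a physicochemical assay for lipophilicity, at pH 7.4; a lower number here means a more polar compound, a higher number a more lipophilic compound:
- compound 1 `Cc1[nH]c2ccccc2c(=O)c1Br`: 1.67
- compound 2 `COc1ccc2[nH]c(C)c(Br)c(=O)c2c1`: 1.62
- compound 3 `Cc1[nH]c2ccc(F)cc2c(=O)c1Br`: 1.61

Compound 1, at 1.67, stands level with the other two within the scatter. Compound 4 `CCCCC#Cc1c(C)[nH]c2ccccc2c1=O` carries hex-1-yn-1-yl in place of bromo on an aromatic carbon. The measured steps are small: a number 0.05 log units lower from compound 1 to compound 2 (within the scatter) with methoxy, a number 0.06 log units lower from compound 1 to compound 3 (within the scatter) with fluoro, and a number 0.01 log units lower from compound 2 to compound 3 (within the scatter) between those two. None of them touches the bromo, so they offer only weak guidance here. The expectation therefore rests on the structural change, where a carbon chain replacing a single bromine points to a higher number in this assay, well beyond the scatter. The expected size is a number 1.53 log units higher from compound 1 to compound 4 (beyond the scatter). Compound 4 is therefore estimated at 3.2, with a range of 2.7 to 3.8.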

Compound 4, distribution coefficient: 5.44
Compound 4: the middle estimate sits 2.24 log units below what was measured; the measured number lies above the stated range.
By their numbers in this assay, from the lowest: compounds 3, 2 and 1 (each within the scatter of the next); then compound 4.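

This position on the core of compound 1 can shift the reading strongly: in this assay, the number moves a number 3.77 log units higher from compound 1 to compound 4 (beyond the scatter) when hex-1-yn-1-yl replaces bromo. The methoxy and fluoro changes elsewhere on the core gave no such shift, staying within the scatter. Nothing measured here accounts for the size of this step.

On these data alone, how much of the step belongs to the chain length and how much to the triple bond remains open. A saturated hexyl chain, a shorter propynyl chain or an amine at this same carbon would help separate them.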